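A few compounds are considered here, and "the series" means these few. Any claim that something is new, unique, unknown or untested is made for them only; others in the source may bear on it.

Three compounds that share one core and differ in a single group have been measured in a physicochemical assay for solubility, read by spectrophotometry, in phosphate buffer, with a stated time of 18 h, at pH 7.4 (a lower number here means a less soluble compound, a higher number a more soluble compound), so far. Compound 1 `CCc1ccc(-c2nc3c(c(C)nn3-c3ccccc3)c(-c3ccccc3[N+](=O)[O-])c2C#N)cc1` carries nitro and gives 1200 nM. Compound 2 `CCc1ccc(-c2nc3c(c(C)nn3-c3ccccc3)c(-c3ccccc3C(=O)O)c2C#N)cc1` carries carboxy and gives 33000 nM. Compound 3 `CCc1ccc(-c2nc3c(c(C)nn3-c3ccccc3)c(-c3ccccc3C(F)(F)F)c2C#N)cc1` carries trifluoromethyl and gives 11000 nM, the second highest of the three numbers.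

Compound 4 `C#Cc1ccccc1-c1c(C#N)c(-c2ccc(CC)cc2)nc2c1c(C)nn2-c1ccccc1` has ethynyl in place of trifluoromethyl on an aromatic carbon, ortho to a large group: ethynyl in place of trifluoromethyl on an aromatic carbon.

Swapping this group has already moved the number clearly. The measured steps are a 9.2-fold higher number from compound 1 to compound 3 (0.96 log units; beyond the scatter), a 3.0-fold lower number from compound 2 to compound 3 (0.48 log units; beyond the scatter) and, the largest, a 28-fold higher number from compound 1 to compound 2 (1.44 log units; beyond the scatter). None of them involves ethynyl, so the evidence is indirect. The expectation rests on the span from compound 1 at 1200 nM to compound 2 at 33000 nM, with ethynyl placed near its middle.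

In this assay a modest fall is therefore expected, namely a 2.2-fold lower number from compound 3 to compound 4 (0.34 log units; beyond the scatter). For compound 4 the estimate is 5000 nM, with an expected range from 1500 nM to 15000 nM.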

Compound 4, solubility: 46000 nM
Beside the measured number, compound 4's estimate is 9.2-fold (0.96 log units) below it; the measured number lies above the stated range.
By their numbers in this assay, from the lowest: compound 1; then compound 3; then compounds 2 and 4 (each within the scatter of the next).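

In this assay, ethynyl on this aromatic carbon, ortho to a large group, reads level with carboxy (a 1.4-fold higher number from compound 2 to compound 4 (0.14 log units; within the scatter)), so carboxy is no longer alone at the top of the series. The change from trifluoromethyl also gives a clear rise (a 4.2-fold higher number from compound 3 to compound 4 (0.62 log units; beyond the scatter)), and the gap to nitro is large (a 38-fold higher number from compound 1 to compound 4 (1.58 log units; beyond the scatter)), which shows that a group with no hydrogen-bond donors or acceptors and no net charge can match carboxy at this position. Nothing measured here explains these differences.

As far as these compounds go, whether an amine, a methyl group or a longer chain ending in a triple bond would reach the same level at this place stays open. All four compounds also share one core, and whether this order of groups holds on any other core is not shown.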